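The source may report more compounds than this note shows. Statements on the series, on what has been measured and on what is new or still open speak of the compounds shown alone.

Values so far in a functional assay on a cell-free system (Platelet, plasma, Homo sapiens) for inhibition, with stated times of 1 min and 3 min (on this read-out lower numbers stand for stronger inhibition and higher numbers for weaker inhibition), are these:
compound 1 `CCSc1nc(NCc2ccc(OC)cc2)c2ncn([C@@H]3O[C@H](CO)[C@@H](O)[C@H]3O)c2n1` gives "not determined" (no result reported)
compound 2 `CC(C)Sc1nc(NC2CCCCC2)c2ncn([C@@H]3O[C@H](CO)[C@@H](O)[C@H]3O)c2n1` gives 187000 nM
compound 3 `CCCCCCNc1nc(SCC)nc2c1ncn2[C@@H]1O[C@H](CO)[C@@H](O)[C@H]1O` gives "not determined" (no result reported)

Going by the values given here, compound 2 at 187000 nM holds the only number, so it cannot yet be ranked against any other compound. Among the compounds with values here, compound 1 and compound 3 have no reported result, and no step between measured compounds is available to show how far a single change can move this assay.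

The next compound is compound 4 `CCCSc1nc(NC2CCCCC2)c2ncn([C@@H]3O[C@H](CO)[C@@H](O)[C@H]3O)c2n1`, which has the same atoms as compound 2, joined differently. The change is propyl in place of isopropyl on a sulfur, with the rest of the structure unchanged.

Within the data shown here, with no measured step to calibrate against, the expectation rests on compound 2 alone, at 187000 nM as the starting point. No clear direction is expected, and the expected change is no larger than the usual scatter. Among the measured compounds shown here, the estimated change a 1.1-fold lower number from compound 2 to compound 4 (0.04 log units; within the scatter) therefore counts as no real step. The estimate for compound 4 is 170000 nM, with the measurement expected to fall between 60000 nM and 450000 nM in this read-out.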

Compound 4, half-maximal inhibitory concentration: 151000 nM
Compound 4: middle estimate off by 1.1-fold (0.05 log units), on the high side, and the stated range covers the measured number.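

In this assay, going by these compounds alone, a 1.2-fold lower number from compound 2 to compound 4 (0.09 log units; within the scatter), the first step that can be read. Propyl in place of isopropyl on a sulfur therefore does not separate compound 2 and compound 4, so this exchange at this position gives no sign of a real effect on the read-out. Nothing available bears on an explanation of this result.

Within the data shown here, the step covers only one exchange between two groups with the same atoms, so it says little about how the position responds to a real change in the group. Still open, as far as these compounds go, is whether a longer chain such as octyl on the sulfur, or an amine or a carboxylic acid at the end of the propyl chain, would move the number beyond the scatter.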